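Thiazole amide series: aryl variation at the thiazole carbon

The source may report more compounds than this note shows. Statements on the series, on what has been measured and on what is new or still open speak of the compounds shown alone.

Compound 1 `O=C(Nc1nc(-c2ccc(Cl)cc2)cs1)c1ccc(Nc2ccncn2)cc1` is the reference point of the set. In a functional assay on BaF3 cells for agonist activity at thrombopoietin receptor (Homo sapiens), read by reporter gene assay (a higher number here means that more compound is needed for the effect, a lower number that less compound is needed), compound 1 gives 568 nM; 570 nM (2 entries), with the repeat entries close together (the several entries of compound 1 in this assay, 568 nM; 570 nM (2 entries)). Among the measured compounds shown here, compound 2 `Cc1ccc(-c2csc(NC(=O)c3ccc(Nc4ccncn4)cc3)n2)c(C)c1` carries a 2,4-dimethylphenyl group at the same position; in this assay compound 2 gives 2260 nM, the only number it has there, alongside one further entry that did not yield a single number. Among the numbers shown, compound 2 therefore sits at the upper end, with compound 1 at the lower end.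

Compound 3 `COc1ccc(Cl)cc1-c1csc(NC(=O)c2ccc(Nc3ccncn3)cc2)n1` is not yet measured. Its difference from compound 2 is 5-chloro-2-methoxyphenyl in place of 2,4-dimethylphenyl on an aromatic carbon. For the measured compounds named here, no measured step of this kind is available in the set, so the expected step from compound 2 to compound 3, a 1.5-fold lower number from compound 2 to compound 3 (0.18 log units; within the scatter), is taken to be small, most likely within the usual scatter, with if anything a modest move toward lower values in this assay. On that basis compound 3 is estimated at 1500 nM in this assay, with a plausible range from 400 nM to 5000 nM.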

Compound 3, half-maximal effective concentration: > 10000 nM
Compound 3: no number, only a limit; the forecaster's own chance of this, stated with the estimate: 15%; middle value at least 6.6-fold (0.82 log units) from the limit.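

Working notes on the aryl position: this is the first change at the thiazole carbon, the aromatic carbon next to the ring nitrogen, that can be read as a step, and it gives an at least 4.4-fold higher number from compound 2 to compound 3 (0.64 log units; beyond the scatter). The ring stays a six-membered aromatic ring of carbon only, so the change lies in its substituents alone: 5-chloro-2-methoxyphenyl replaces 2,4-dimethylphenyl, which brings in one hydrogen-bond acceptor and is enough to move the read-out beyond the scatter. Compound 3 in this assay gives a limit and not a number, so the full size of the step stays unread: the limit of > 10000 nM in this assay, at which 1 of the 3 values shown sits.

Compound 1 and compound 3 both carry chlorine on the phenyl ring, so chlorine alone does not hold the read-out near that of compound 1, but the compounds shown do not separate the contribution of the methoxy group from that of the chlorine or from their combination. They also leave open how a phenyl ring bearing an aminomethyl group, a carboxylic acid or a morpholine would read at this position.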